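Nitro for methoxy on the ester-linked aromatic ring

The compounds below may be only part of what the source reports. "The series", "measured", "known", "first", "only" and "open" are said of these compounds alone.

Compound 1, `COc1ccc(C(=O)Oc2cc3c(cc2C)[C@@H](C(C)C)CC=C3C)cc1`, gives 18.6%.
Compound 2, `COc1ccc(C(=O)Oc2cc3c(C)ccc(C(C)C)c3cc2C)cc1`, gives 32.8%.
Compound 3, `CC1=CC[C@H](C(C)C)c2cc(C)c(OC(=O)c3cccc(C(F)(F)F)c3)cc21`, gives 18.3%.

These three compounds were tested in a functional assay on SK-LU-1 cells (Homo sapiens) for antiproliferative activity, read by sulforhodamine B assay, with a stated time of 48 h, tested at 50 uM; a higher number here means more inhibition at the concentration tested (going by the name of the read-out), a lower number less inhibition. Compound 2 stands highest of the three. Compound 1 sits below it by a gap that lies beyond the usual scatter of repeated measurements, and compound 3 sits furthest below, also beyond the scatter. Within the data shown here, no pair among the three differs in one place only, so none of these gaps can be read as the effect of a single structural change; each compound carries an ester that links the shared core to a substituted benzene ring, and the cores differ as well.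

Compound 4, `Cc1cc2c(C(C)C)ccc(C)c2cc1OC(=O)c1ccc([N+](=O)[O-])cc1`, has not yet been measured. It is built from compound 2 by one change: nitro in place of methoxy on an aromatic carbon. The swap sits on the six-membered aromatic ring of carbon only, para to a large group, while the core of compound 2 is kept. Among the measured compounds shown here, no measured pair shows what such a swap does in this assay, so the step is expected to be small, within the scatter, with no clear direction. For compound 4 the estimated inhibition is 31%, ranging from 16% to 46%, which as a step means a number 1.8 percentage points lower from compound 2 to compound 4 (within the scatter).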

Compound 4, a percentage reported as inhibition, at one concentration (the size of the read-out at that concentration, not a potency): 100%
For compound 4 the middle estimate is 69 percentage points below the measured one; measured number above the stated range.
By their numbers in this assay, from the lowest: compounds 3 and 1 (each within the scatter of the next); then compound 2; then compound 4.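

Among these compounds, compounds 2 and 4 are the first pair here that differ in one place only, so this gap can be read as the effect of a single change: in this assay, nitro in place of methoxy gives a number 67.2 percentage points higher from compound 2 to compound 4 (beyond the scatter) with the core of compound 2 kept intact. The result shows that this aromatic carbon, para to a large group, is far from a silent position, since the group placed there can by itself separate the modest inhibition of compound 2 from the much fuller inhibition of compound 4. Nothing in the data shown accounts for why this one change has so large an effect.

A single step cannot show whether the rise belongs to nitro specifically, or whether an amine, a carboxylic acid or a nitrile on the same carbon would give something similar. On these data alone, it also remains open whether the same swap would lift compound 1 from 18.6% in the same way on its different core, so the step cannot yet be carried beyond the core of compound 2.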